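The compounds below may be only part of what the source reports. "The series", "measured", "known", "first", "only" and "open" are said of these compounds alone.

Three compounds here share one core. Compound 1 `CC(C)CC1OCCC(Cl)=C1[Si](C)(C)C` gives 92000 nM in a functional assay on A2780 cells (Homo sapiens) for antiproliferative activity; on this read-out higher numbers stand for lower toxicity in this test and lower numbers for higher toxicity in this test. Compound 2 `C[C@H]1CC(Cl)=C([Si](C)(C)C)[C@@H](C2CCCCC2)O1` gives 61000 nM in this assay, and compound 3 `C[C@@H]1O[C@H](C2CCCCC2)C([Si](C)(C)C)=C(Cl)[C@H]1C` gives 77000 nM in this assay, the second highest of the three numbers. Among the compounds with values here, the only single-point step among them, a 1.3-fold higher number from compound 2 to compound 3 (0.10 log units; within the scatter), lies within the scatter. Compound 4 `C#CCC[C@H]1O[C@@H](C)[C@H](C)C(Cl)=C1[Si](C)(C)C` differs from compound 3 by but-3-yn-1-yl in place of cyclohexyl on a saturated ring carbon. Within the data shown here, no measured step swaps a ring for a chain at that position, so no direction is known; compound 1, bearing a chain, and compound 2, bearing a cyclohexyl, give numbers in the same broad range. Compound 4 is therefore expected to move no further than a 1.0-fold higher number from compound 3 to compound 4 (0.02 log units; within the scatter). The estimate for compound 4 in this assay is 80000 nM, with a range from 30000 nM to 200000 nM.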

Compound 4, concentration lethal to 50% of the cells: 75000 nM
Compound 4: the middle estimate sits 1.1-fold (0.03 log units) above what was measured; the range from low to high includes it.
By their numbers in this assay, from the lowest: compounds 2, 4, 3 and 1 (each within the scatter of the next).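

Putting but-3-yn-1-yl in place of cyclohexyl on this saturated ring carbon gives a 1.0-fold lower number from compound 3 to compound 4 (0.01 log units; within the scatter) in this assay. Within the data shown here, this is the first direct ring-for-chain comparison at this position, and it shows that, in this pair, an open chain with a triple bond can replace the carbon ring without a change beyond the scatter. Nothing available explains this result. Still open, from the compounds shown here alone, is whether an amine, a carboxylic acid or a longer chain here would leave the number as little moved. A plain butyl chain could also show whether the triple bond matters.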